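The compounds below may be only part of what the source reports. "The series", "measured", "known", "first", "only" and "open" are said of these compounds alone.

Three compounds share a core, differing in the group on the amine nitrogen. In an assay on CHO cells for displacement of a labelled ligand from 5-hydroxytryptamine receptor 1D (Homo sapiens) (on this read-out higher numbers stand for weaker inhibition and lower numbers for stronger inhibition), compound 1 `O[C@H]1Cc2ccccc2C1NC1CCN(CCCc2c[nH]c3ccc(-n4cnnc4)cc23)CC1` gives 37 nM, compound 2 `c1cc(CNC2CCN(CCCc3c[nH]c4ccc(-n5cnnc5)cc34)CC2)co1` gives 4.5 nM, and compound 3 `c1ccc(CNC2CCN(CCCc3c[nH]c4ccc(-n5cnnc5)cc34)CC2)cc1` gives 4.6 nM. Compound 3 thus sits second highest of the three, within the scatter of compound 2 and well below compound 1. Compound 4 `c1ccc2c(c1)CCC2NCC1CCN(CCCc2c[nH]c3ccc(-n4cnnc4)cc23)CC1` differs from compound 3 by ((2,3-dihydro-1H-inden-1-yl)amino)methyl in place of benzylamino on a saturated ring carbon. The step that bears on this is an 8.0-fold lower number from compound 1 to compound 3 (0.91 log units; beyond the scatter), where a benzyl replaced a ring-fused group of the same kind; compound 4 partly reverses that change, though with an added methylene and without the hydroxyl, so a modest rise in the number is expected. For compound 4 in this assay the estimate is 18 nM, with a range from 6 nM to 60 nM, meaning an expected step of a 3.9-fold higher number from compound 3 to compound 4 (0.59 log units; beyond the scatter).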

Compound 4, half-maximal inhibitory concentration: 1.1 nM
Beside the measured number, compound 4's estimate is 16-fold (1.21 log units) above it, outside the stated range (below it).
By their numbers in this assay, from the lowest: compound 4; then compounds 2 and 3 (each within the scatter of the next); then compound 1.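

In this assay, ((2,3-dihydro-1H-inden-1-yl)amino)methyl on the saturated ring carbon gives a 4.2-fold lower number from compound 3 to compound 4 (0.62 log units; beyond the scatter) and a 4.1-fold lower number from compound 2 to compound 4 (0.61 log units; beyond the scatter), so a five-membered non-aromatic ring fused to the aromatic ring is compatible with a low number here. The comparison with the hydroxylated group gives a 34-fold lower number from compound 1 to compound 4 (1.53 log units; beyond the scatter), but the hydroxyl and the added methylene change together, so their contributions cannot be separated. No available evidence explains these steps. Open, going by these compounds, is whether benzylaminomethyl at this ring carbon would lower the number without the five-membered ring.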